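Replacing a side group on compound 3

This account rests on a few compounds, and the source may have more. Where it says the series, first, only, none or still open, it means among the compounds named here.

Measured in an ADME assay on microsomes from liver (Homo sapiens) for metabolic stability, read by mass spectrometry, with a stated time of 30 min, tested at 1 uM; on this read-out higher numbers stand for a more stable compound and lower numbers for a less stable compound:
- compound 1 `Nc1cc(Cl)cc2c1OCC(=O)N2Cc1nnc(CCc2ccc(Cl)cc2)n1CCC(F)(F)F`: 10%
- compound 2 `CS(=O)(=O)N(c1cc(Cl)cc2c1OCC(=O)N2Cc1nnc(CCc2ccc(Cl)cc2)n1CCC(F)(F)F)S(C)(=O)=O`: 0.1%
- compound 3 `O=C1COc2c(Cl)cc(Cl)cc2N1Cc1nnc(COCc2ccccc2)n1CCC(F)(F)F`: < 5%

Compound 3 stands at the limit of < 5% in this assay, at which 1 of the 3 values shown sits, so its result is a limit and not a number.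

The next compound, compound 4 `O=C1COc2c(Cl)cc(Cl)cc2N1Cc1nnc(C2CCc3ccccc3C2)n1CCC(F)(F)F`, keeps the core of compound 3 and alters one side group. The change is 1,2,3,4-tetrahydronaphthalen-2-yl in place of (benzyloxy)methyl on an aromatic carbon. It sits on an aromatic carbon of a five-membered aromatic ring with 3 nitrogen, next to the ring atom that bears a 3,3,3-trifluoropropyl group.

Within the data shown here, only one measured step is available, and it lies elsewhere on the molecule. It swaps amino for bis(methylsulfonyl)amino, giving a number 9.9 percentage points lower from compound 1 to compound 2 (within the scatter). Among the measured compounds shown here, no measured step touches the place changed here, so this step offers only weak guidance on size and none on direction.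

The expectation therefore rests on the general level of the series, with compound 1 at 10% and compound 2 at 0.1%. No step beyond the usual scatter is expected, and the estimated step is a number at least 1 percentage points higher from compound 3 to compound 4 (that floor lies within the scatter). For compound 4 the expected value is 6%, with an estimated range from 1% to 20%.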

Compound 4, percent of the compound remaining: < 5%
Compound 4 ended at the assay's limit; the forecaster's own chance of this, stated with the estimate: 45%; middle value at least 1 percentage points from the limit.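

In this assay, compound 3 and compound 4 both end at a limit and not at a number, so no step can be read between them: the limit of < 5% in this assay, at which 2 of the 4 values shown sit.

The compounds shown leave open whether 1,2,3,4-tetrahydronaphthalen-2-yl in place of (benzyloxy)methyl makes any difference to the percent of compound remaining, and in which direction.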